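From Ethyl to Methoxy: What to Expect for Compound 3

This account rests on a few compounds, and the source may have more. Where it says the series, first, only, none or still open, it means among the compounds named here.

Compound 1 `CCc1ccc(NS(=O)(=O)c2ccc(N3CCNC3=O)cc2)cc1` gives 480 nM in a functional assay on M21 cells (Homo sapiens) for antiproliferative activity, read by sulforhodamine B assay, with a stated time of 48 h (on this read-out higher numbers stand for weaker inhibition and lower numbers for stronger inhibition), the highest of the two numbers recorded so far. Compound 2 `O=C1NCCN1c1ccc(S(=O)(=O)Nc2ccccc2)cc1` gives 200 nM in this assay. Among the measured compounds shown here, the one measured step, a 2.4-fold lower number from compound 1 to compound 2 (0.38 log units; beyond the scatter), shows that hydrogen in place of ethyl shifts the number downward. Compound 3 `COc1ccc(NS(=O)(=O)c2ccc(N3CCNC3=O)cc2)cc1` differs from compound 1 by methoxy in place of ethyl on an aromatic carbon. For the measured compounds named here, only that single step bears on this change, and it involves a different entering group, so a modest downward step is expected, a 1.6-fold lower number from compound 1 to compound 3 (0.20 log units; within the scatter), with little confidence. Compound 3 is therefore estimated at 300 nM, within a range from 100 nM to 900 nM.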

Compound 3, half-maximal inhibitory concentration: 580 nM
For compound 3 the middle estimate is 1.9-fold (0.29 log units) below the measured one; low and high end bracket the measured number.
By their numbers in this assay, from the lowest: compound 2; then compounds 1 and 3 (each within the scatter of the next).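

Methoxy in place of ethyl gives a 1.2-fold higher number from compound 1 to compound 3 (0.08 log units; within the scatter) in this assay and so, at this position, these two groups cannot be told apart. Methoxy in place of hydrogen gives a 2.9-fold higher number from compound 2 to compound 3 (0.46 log units; beyond the scatter) and so compound 2, with hydrogen here, now stands apart from both substituted compounds, not from the ethyl compound alone. Nothing available explains why ethyl and methoxy give such similar numbers.

Still open, going by these compounds, is whether an amine, a carboxylic acid or a longer chain at this position would stay close to ethyl and methoxy or come nearer to hydrogen. The compounds shown also leave open whether a halogen such as fluorine would do the same.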